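Cytotoxicity notes on a naphthyl hydroxy-amidrazone series

This account rests on a few compounds, and the source may have more. Where it says the series, first, only, none or still open, it means among the compounds named here.

Measured compounds:
compound 1, `N/C(CC(O)c1cccc2ccccc12)=N\N=C\c1ccc(Cl)c(Cl)c1`, 16000 nM
compound 2, `C/C(=N\N=C(/N)CC(O)c1cccc2ccccc12)c1ccc(F)cc1`, 34000 nM
compound 3, `CCOc1cc(/C=N/N=C(\N)CC(O)c2cccc3ccccc23)ccc1O`, 4200 nM

All three share the same core and differ in the aryl group attached to the carbon with a double bond to nitrogen. In an ADME assay on L6 cells (Rattus norvegicus) for cytotoxicity, read by resazurin assay, with a stated time of 72 h (on this read-out higher numbers stand for weaker inhibition and lower numbers for stronger inhibition), compound 1 gives 16000 nM, which places it second highest of the three numbers. Compound 2 gives 34000 nM, a higher number, and the gap to compound 1 lies beyond the scatter. Compound 3 gives 4200 nM, the lowest number of the set, and its gap to compound 1 also lies beyond the scatter. No two of these compounds differ in a single place, so no step within the measured set can be stated; only the three values themselves are known.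

The unmeasured compound 4, `N/C(CC(O)c1cccc2ccccc12)=N\N=C\c1cccnc1`, follows from compound 1 by one change: pyridin-3-yl in place of 3,4-dichlorophenyl on a carbon with a double bond to nitrogen. Going by the values given here, no measured pair shows this change, so there is no direct precedent for its size in this assay. The expectation is a modest upward move, the estimated step being a 1.9-fold higher number from compound 1 to compound 4 (0.27 log units; within the scatter), which stays close to the scatter. In this assay compound 4 is therefore expected to give about 30000 nM, with a likely range from 10000 nM to 90000 nM.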

Compound 4, half-maximal inhibitory concentration: 22000 nM
The estimate for compound 4 lay 1.4-fold (0.13 log units) above the measured number; measured number inside the range.
By their numbers in this assay, from the lowest: compound 3; then compounds 1, 4 and 2 (each within the scatter of the next, the first and the last beyond it).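

Going by these compounds alone, this is the first comparison that differs in one place: with pyridin-3-yl in place of 3,4-dichlorophenyl on a carbon with a double bond to nitrogen, this assay shows a 1.4-fold higher number from compound 1 to compound 4 (0.14 log units; within the scatter). At this position, then, an exchange that gives up both chlorine atoms and brings in a ring with 1 hetero atom and 1 hydrogen-bond acceptor leaves compound 1 and compound 4 indistinguishable on this read-out, so this particular change has no effect that can be resolved here. No measurement is available that would account for this result.

Going by these compounds, it remains open whether the same position would tolerate a more drastic replacement, such as a carboxylic acid, a dimethylamino group or a saturated piperidine ring in place of the aromatic group. Within the data shown here, it is also open whether the same exchange would stay within the scatter on a compound that carries a methyl group on that carbon, as compound 2 does, since no single-place pair covers that case.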